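Swapping amino for chloro on a shared core

The source may report more compounds than this note shows. Statements on the series, on what has been measured and on what is new or still open speak of the compounds shown alone.

Compound 1 `Nc1nc2cc(Cl)c(Cl)cc2n1Cc1ccc(Cl)cc1`, compound 2 `COc1ccc(Cn2c(N)nc3cc(Cl)c(Cl)cc32)cc1` and compound 3 `CC(C)(C)c1ccc(Cn2c(N)nc3cc(Cl)c(Cl)cc32)cc1` share one core and differ only in the group on the pendant benzyl ring. In a functional assay on KB cells (Homo sapiens) for inhibition (on this read-out lower numbers stand for stronger inhibition and higher numbers for weaker inhibition), compound 1 gives 45000 nM, compound 2 gives 45000 nM and compound 3 gives 50000 nM. The steps of no change at the digits printed from compound 1 to compound 2 (within the scatter) and a 1.1-fold higher number from compound 2 to compound 3 (0.05 log units; within the scatter) both sit within the scatter, so compound 2 stands level with compound 1 and, within the scatter, with compound 3 as well. Compound 4 `COc1ccc(Cn2c(Cl)nc3cc(Cl)c(Cl)cc32)cc1` departs from compound 2 by chloro in place of amino on an aromatic carbon. Among the compounds with values here, none of the three measured steps touches this part of the core; each alters only the benzyl ring, so no measured step bears on this change. The expected step of no change at the digits printed from compound 2 to compound 4 (within the scatter) is therefore none beyond the scatter, with wide uncertainty. Compound 4 is estimated at 45000 nM, ranging from 15000 nM to 150000 nM.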

Compound 4, half-maximal inhibitory concentration: > 100000 nM
Compound 4 gave a limit, no number; the forecaster's own chance of this, stated with the estimate: 30%; at least 2.2-fold (0.34 log units) between middle value and limit.
By their numbers in this assay, from the lowest: compounds 1, 2 and 3 (each within the scatter of the next). At a limit, above all of these: compound 4.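

The steps among compounds 1, 2 and 3 alter only the benzyl ring and all stay within the scatter, whereas this change, on the aromatic carbon between two ring nitrogen atoms, goes beyond it in this assay, with an at least 2.2-fold higher number from compound 2 to compound 4 (0.34 log units; beyond the scatter). Among the compounds shown, then, the number responds to this position on the shared core, where amino gives way to chloro. Compound 4 gives no number, only a limit of the assay: the limit of > 100000 nM in this assay, at which 1 of the 4 values shown sits.

Open, on these data alone, is what a methylamino group or a hydroxyl group at this carbon would give. Also open, as far as these compounds go, is whether chloro in place of amino has the same outcome with chloro or tert-butyl on the benzyl ring.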